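The source may hold more compounds than are shown below. What is called first, only, known or untested is meant among the compounds shown, and "the series" means these compounds.

Measured in a functional assay on MIA PaCa-2 cells (Homo sapiens) for antiproliferative activity; a lower number here means that less compound is needed, a higher number that more compound is needed for the effect:
- compound 1 `C#CCNC(=O)c1cccc2c1cc(C)n2-c1nc2c(c(NCc3ccccc3)n1)COCC2`: 1080 nM
- compound 2 `CC#CC(=O)Nc1cccc2c1cc(C)n2-c1nc2c(c(NCc3ccccc3)n1)CCCC2`: 436 nM
- compound 3 `CCCC#CC(=O)Nc1cccc2c1cc(C)n2-c1nc2c(c(NCc3ccccc3)n1)CCCC2`: 1570 nM

Compound 1 lies within the scatter of compound 3 and has a higher number than compound 2. Compound 4 `C#CC(=O)Nc1cccc2c1cc(C)n2-c1nc2c(c(NCc3ccccc3)n1)COCC2` changes its side chain: (ethynylcarbonyl)amino in place of propargylcarbamoyl on an aromatic carbon. Among the measured compounds shown here, no measured step makes this exchange. The nearest evidence is a 3.6-fold higher number from compound 2 to compound 3 (0.56 log units; beyond the scatter), on a different core, where ethyl replaces hydrogen on the chain. A modest fall in the number is therefore expected in this assay, as compound 2, with the shorter chain, gives 436 nM. The expected change is a 2.4-fold lower number from compound 1 to compound 4 (0.38 log units; beyond the scatter). For compound 4 the estimated value is 450 nM, with an expected range of 130 nM to 1600 nM.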

Compound 4, half-maximal effective concentration: 78.7 nM
Compound 4: middle estimate off by 5.7-fold (0.76 log units), on the high side; the measured number lies below the stated range.
By their numbers in this assay, from the lowest: compound 4; then compound 2; then compounds 1 and 3 (each within the scatter of the next).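

In this assay, (ethynylcarbonyl)amino in place of propargylcarbamoyl on an aromatic carbon gives a 14-fold lower number from compound 1 to compound 4 (1.14 log units; beyond the scatter), a large step. The earlier compounds shown here showed only a change at the far end of the chain, whereas this step shows that exchanging the whole group at this position can move the number strongly. No measurement given here explains the step.

On these data alone, it remains open whether the same exchange would act similarly on another core. Also open, as far as these compounds go, is how acryloylamino or propanoylamino would compare with (ethynylcarbonyl)amino at this aromatic carbon.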